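The source may hold more compounds than are shown below. What is called first, only, known or untested is meant among the compounds shown, and "the series" means these compounds.

Series of amides built on a shared core, compared in a functional assay (Cavia porcellus) with sulfonylurea receptors; K-ATP channels (Homo sapiens) as the target; on this read-out higher numbers stand for weaker inhibition and lower numbers for stronger inhibition.

Going by the values given here, compound 1 (`CC(O)(C(=O)Nc1ccc(S(=O)(=O)c2ccccc2Cl)cc1)C(F)(F)F`) gives 2300 nM in this assay; it is the only numerical value in the set so far. Compound 2 (`CC(O)(C(=O)Nc1ccc(C(=O)c2cccc(Cl)c2)cc1)C(F)(F)F`) returns only a limit in this assay, > 30000 nM, and no number. Of the two values shown, compound 1 stands at a number and compound 2 at the limit described by the limit of > 30000 nM in this assay, at which 1 of the 2 values shown sits.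

Compound 3 (`CC(O)(C(=O)Nc1ccc(S(=O)(=O)c2ccccn2)cc1)C(F)(F)F`) carries pyridin-2-yl in place of 2-chlorophenyl on a sulfonyl sulfur, so the chlorine-bearing ring of compound 1 gives way to a ring holding one nitrogen. Among the compounds with values here, no measured pair in the set isolates such a change, so nothing here supports a firm expectation of direction. The working expectation is a modest step toward weaker inhibition, a 2.2-fold higher number from compound 1 to compound 3 (0.34 log units; beyond the scatter), in this assay. Compound 3 is accordingly estimated at 5000 nM in this assay, with a likely range from 1500 nM to 20000 nM.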

Compound 3, half-maximal inhibitory concentration: 600 nM
Compound 3: middle estimate off by 8.3-fold (0.92 log units), on the high side; the whole stated range lies above it.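

On a sulfonyl sulfur whose other neighbours are aromatic carbon, the 2-chlorophenyl ring is not required for inhibition in this assay, as pyridin-2-yl in its place gives a 3.8-fold lower number from compound 1 to compound 3 (0.58 log units; beyond the scatter). Going by these compounds alone, this is the first step that changes one place only, and it gives this position a measured direction: the ring holding one nitrogen reads stronger than the chlorine-bearing ring, beyond the usual scatter. No measured property in the set bears on this step.

The change removes the chlorine and introduces the ring nitrogen together, and the two contributions remain unseparated; an unsubstituted phenyl on the same sulfur would divide them. Also open, from the compounds shown here alone, is how a ring with a second nitrogen, such as pyrimidin-2-yl, would read at this position in this assay.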